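The source may hold more compounds than are shown below. What is called first, only, known or untested is meant among the compounds shown, and "the series" means these compounds.

In a functional assay on PANC-1 cells (Homo sapiens) for inhibition, read by MTT assay, with a stated time of 24 h, tested at 10 uM (on this read-out higher numbers stand for more inhibition at the one concentration tested (going by the name of the read-out) and lower numbers for less inhibition), compound 1 `CC(C)=CCC/C(C)=C/CC1Cc2c(O)cc(=O)n(CCCO)c2CC1(C)C` gives 0%; compound 2 `CC(C)=CCC1Cc2c(OCCCNC(=O)c3cccs3)cc(=O)n(CCCO)c2CC1(C)C` gives 5.6% in this assay, a gap that stays inside the usual scatter, so the two values read as one level near no inhibition. Compound 3 `CC(C)=CCC/C(C)=C/CC1Cc2c(OC(=O)Nc3ccc(Cl)c(Cl)c3)cc(=O)n(CCCO)c2CC1(C)C` differs from compound 1 by (3,4-dichlorophenyl)carbamoyl in place of hydrogen on an oxygen on an aromatic ring. For the measured compounds named here, no step between two measured compounds is known, so the size of this change cannot be read off from data; a modest rise is expected, a number 15 percentage points higher from compound 1 to compound 3 (beyond the scatter), rather than none. Compound 3 is expected to give 15% in this assay, with a range from 0% to 45%.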

Compound 3, a percentage reported as inhibition, at one concentration (the size of the read-out at that concentration, not a potency): 0%
For compound 3 the middle estimate is 15 percentage points above the measured one; measured number inside the range.
By their numbers in this assay, from the lowest: compounds 1, 3 and 2 (each within the scatter of the next).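

In this assay, (3,4-dichlorophenyl)carbamoyl in place of hydrogen on an oxygen on an aromatic ring gives no change at the digits printed from compound 1 to compound 3 (within the scatter). Compound 1 already stands at 0%, so this step could show only a rise in inhibition, and none appears; any loss at this oxygen stays invisible. No measurement at hand explains this result.

On these data alone, whether a smaller group on this oxygen, such as acetyl or methyl, behaves the same remains open. So does the outcome with a chain ending in an amine or a carboxylic acid.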